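Fluoro on the Pyridine of a Thiomorpholine Thiosemicarbazide

The source may hold more compounds than are shown below. What is called first, only, known or untested is meant among the compounds shown, and "the series" means these compounds.

Measured in a functional assay on HeLa cells (Homo sapiens) for cytotoxicity, read by MTT assay, with a stated time of 72 h, tested at 10 uM; on this read-out lower numbers stand for less inhibition of growth and higher numbers for more inhibition of growth at the one concentration tested:
compound 1 `N/C(=N\NC(=S)N1CCCC1)c1ccc(F)cn1` gives 72.7%
compound 2 `N/C(=N\NC(=S)N1CCSCC1)c1ccccn1` gives 54.5%

Of these two numbers in this assay, compound 2 stands lowest, with compound 1 higher by a margin beyond the scatter; the two differ in two places, so that gap belongs to neither change alone. Compound 3 `N/C(=N\NC(=S)N1CCSCC1)c1ccc(F)cn1` differs from compound 2 in one place: fluoro in place of hydrogen on an aromatic carbon. For the measured compounds named here, no single step of this kind has been measured here, so the change is expected to amount to a number 7.5 percentage points higher from compound 2 to compound 3 (within the scatter), a small move, more likely upward than downward, and possibly within the scatter. Compound 3 is therefore estimated at 62% in this assay, within a range of 45% to 80%.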

Compound 3, percent growth inhibition at one concentration: 70.5%
For compound 3 the middle estimate is 8.5 percentage points below the measured one, and the stated range covers the measured number.
By their numbers in this assay, from the lowest: compound 2; then compounds 3 and 1 (each within the scatter of the next).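

In this assay, fluoro in place of hydrogen on the aromatic carbon two atoms from the ring nitrogen now has a step of its own, a number 16 percentage points higher from compound 2 to compound 3 (beyond the scatter), which is modest but beyond the scatter. With fluoro in place, thiomorpholin-4-yl in place of pyrrolidin-1-yl on the thiocarbonyl carbon gives a number 2.2 percentage points lower from compound 1 to compound 3 (within the scatter), within the scatter, so of these two changes only the fluoro step registers here. Nothing available explains why this step occurs. Still open, on these data alone, is whether chloro or methoxy on this carbon would give a similar step, and whether fluoro would do the same alongside pyrrolidin-1-yl.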